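A few compounds are considered here, and "the series" means these few. Any claim that something is new, unique, unknown or untested is made for them only; others in the source may bear on it.

Measured compounds:
compound 1, `CC(C)(C)c1ccc(CCC(=O)Nc2ccc3c(c2)OCCO3)cc1`, 150 nM
compound 2, `CC(C)C/C(=C\C(=O)Nc1ccc2c(c1)OCCO2)c1ccc(C(C)(C)C)cc1`, 16 nM
compound 3, `O=C(/C=C/c1ccccc1)Nc1ccc2c(c1)OCCO2`, > 4000 nM

Of the compounds shown here, three sharing one core have been tested in a functional assay on CHO cells for inhibition of transient receptor potential cation channel subfamily V member 1 (Homo sapiens); on this read-out lower numbers stand for stronger inhibition and higher numbers for weaker inhibition. Compound 1 gives 150 nM. Compound 2 gives 16 nM; it differs from compound 1 in several places. For compound 3 the value > 4000 nM is not a number but a limit of this assay, so only an upper bound on its inhibition is known; it sits at the limit of > 4000 nM in this assay, at which 1 of the 3 values shown sits.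

Compound 4, `Cc1ccc(/C=C/C(=O)Nc2ccc3c(c2)OCCO3)cc1`, has not yet been measured. It differs from compound 3 in a single respect: methyl in place of hydrogen on an aromatic carbon, para to a large group, so that a phenyl becomes a 4-methylphenyl.

Within the data shown here, no measured pair shows this exact change, so the step can only be guessed. Compound 1 and compound 2, which both carry a larger group on their outer ring, give numbers in this assay, whereas compound 3 gives only a limit; that hints that substitution there may help, but the start point is itself unknown. The step from compound 3 to compound 4 in this assay is expected to be an at least 1.6-fold lower number from compound 3 to compound 4 (0.20 log units; that floor lies within the scatter). Compound 4 is therefore expected to give about 2500 nM, with a range from 600 nM to 10000 nM.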

Compound 4, half-maximal inhibitory concentration: 210 nM
For compound 4 the middle estimate is 12-fold (1.08 log units) above the measured one; the whole stated range lies above it.
By their numbers in this assay, from the lowest: compound 2; then compounds 1 and 4 (each within the scatter of the next). At a limit, above all of these: compound 3.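

In this assay, turning the phenyl into a 4-methylphenyl gives an at least 19-fold lower number from compound 3 to compound 4 (1.27 log units; beyond the scatter), a large change from a single added carbon. Among these compounds, this is the first comparison here between two compounds that differ in only one place, so this position can be said to matter for inhibition, and a methyl on an aromatic carbon, para to a large group, is enough to bring a compound with no measurable number into the measurable range. The step is only a minimum and the real change could be larger, because compound 3 gives a limit rather than a number: the limit of > 4000 nM in this assay, at which 1 of the 4 values shown sits.

On these data alone, with only hydrogen and methyl compared at this position, it remains open whether a chlorine atom, a methoxy group, an amine or a longer chain such as ethyl would give a similar, larger or smaller change in inhibition. As far as these compounds go, it also remains open whether the same methyl would have a comparable effect on a compound that differs elsewhere, such as one with the saturated chain of compound 1.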